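Solubility notes on the aryloxyacetamide series, compound 4 pending

A few compounds are considered here, and "the series" means these few. Any claim that something is new, unique, unknown or untested is made for them only; others in the source may bear on it.

Measured so far in a physicochemical assay for solubility, in phosphate buffer, measured as kinetic solubility, with a stated time of 1 h, at pH 7.4; on this read-out higher numbers stand for higher solubility and lower numbers for lower solubility:
compound 1, `COc1ccc2nc(C)cc(OCC(=O)Nc3cc(C)cc(C)c3)c2c1`, 26000 nM
compound 2, `Cc1cc(C)cc(NC(=O)COc2cc(C)nc3ccc(C(F)(F)F)cc23)c1`, 10000 nM
compound 3, `COc1ccc2nc(C)cc(OCC(=O)Nc3ccc(Cl)c(C(F)(F)F)c3)c2c1`, 17000 nM

Compound 3 stands nearest to compound 1 and furthest from compound 2; both gaps lie within the scatter of this assay. The difference between the core of compound 3 and the core of compound 2 is not broken down here.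

One change recurs twice among these compounds. From compound 2 to compound 1 it reads methoxy in place of trifluoromethyl on an aromatic carbon and gave a 2.6-fold higher number from compound 2 to compound 1 (0.41 log units; beyond the scatter). From compound 3 to compound 4, `COc1ccc2nc(C)cc(OCC(=O)Nc3ccc(Cl)c(OC)c3)c2c1`, the change is methoxy in place of trifluoromethyl on an aromatic carbon. This is the same kind of change, not the same one: in compound 1 the methoxy sits on a ring that is part of a fused or bridged system of two rings, meta to a fused ring and para to a fused ring, whereas in compound 4 it sits on a six-membered aromatic ring of carbon only, ortho to a chloro group and meta to a large group.

Going by the values given here, for compound 4 the expectation in this assay rests on the one earlier step; compound 4 is expected to give 35000 nM, between 15000 nM and 80000 nM. That estimate means a step of a 2.1-fold higher number from compound 3 to compound 4 (0.31 log units; beyond the scatter) from compound 3, a little smaller than the earlier one because the earlier step of a 2.6-fold higher number from compound 2 to compound 1 (0.41 log units; beyond the scatter) was made in different surroundings and a single step is a thin base. The measured number for compound 4 follows.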

Compound 4, solubility: 13000 nM
The estimate for compound 4 lay 2.7-fold (0.43 log units) above the measured number, and the stated range ends above it.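

In this assay, methoxy in place of trifluoromethyl on the aromatic carbon ortho to a chloro group gives a 1.3-fold lower number from compound 3 to compound 4 (0.12 log units; within the scatter), so the step read on the other core, a 2.6-fold higher number from compound 2 to compound 1 (0.41 log units; beyond the scatter), does not carry over to this ring, and compound 3 and compound 4 cannot be told apart on this read-out. The second new comparison, 4-chloro-3-methoxyphenyl in place of 3,5-dimethylphenyl on an amide-type nitrogen, gives a 2.0-fold lower number from compound 1 to compound 4 (0.30 log units; within the scatter), so that exchange does not separate the two compounds either. With a single pair in each setting, these numbers do not show how the change would read at another ring position or on a further core, and no measurement shown bears on why the two steps read differently.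

The compounds shown leave open how the core of compound 2 would read when carrying the 4-chloro-3-methoxyphenyl group, which would set the two groups side by side on a second core. Also open, from the compounds shown here alone, is how an amine or a carboxylic acid would compare with methoxy and trifluoromethyl on the same aromatic carbon of the shared core of compound 3 and compound 4.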